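Replacing the 4-carboxyphenyl group of compound 3

The compounds below may be only part of what the source reports. "The series", "measured", "known", "first", "only" and "open" are said of these compounds alone.

For compound 3 `CC1(C)Oc2ccc(C#N)cc2[C@@H](/N=C(\NC#N)Nc2ccc(C(=O)O)cc2)[C@@H]1O` the reading in a functional assay (aorta) with Rattus norvegicus as the target (on this read-out higher numbers stand for weaker inhibition and lower numbers for stronger inhibition), is > 100000 nM and this is a limit of the assay, not a number.

Compound 1 `CC1(C)Oc2ccc(C#N)cc2[C@@H](/N=C(\NC#N)Nc2cccc(Cl)c2)[C@@H]1O` reads 600 nM with a 3-chlorophenyl group on the amine nitrogen. Compound 2 `COC(=O)c1cccc(N/C(=N/[C@@H]2c3cc(C#N)ccc3OC(C)(C)[C@H]2O)NC#N)c1` reads 4100 nM with a 3-(methoxycarbonyl)phenyl group there. The step of a 6.8-fold higher number from compound 1 to compound 2 (0.83 log units; beyond the scatter) is modest, while the steps of an at least 160-fold higher number from compound 1 to compound 3 (2.22 log units; beyond the scatter) and an at least 24-fold higher number from compound 2 to compound 3 (1.38 log units; beyond the scatter) are both large.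

Compound 4 `CC1(C)Oc2ccc(C#N)cc2[C@@H](/N=C(\NC#N)Nc2ccc(Cl)c(F)c2)[C@@H]1O` carries 4-chloro-3-fluorophenyl in place of 4-carboxyphenyl on an amine nitrogen. The counted difference is 4-chloro-3-fluorophenyl in place of 4-carboxyphenyl on an amine nitrogen and the rest of the structure stays the same.

Compound 1 is the closest measured match as a chlorophenyl compound, and its step of an at least 160-fold higher number from compound 1 to compound 3 (2.22 log units; beyond the scatter) read in reverse points to a large fall in the number. For the measured compounds named here, no measured compound carries a fluoro group, so the expected range is kept wide. A large step towards stronger inhibition is expected, estimated as an at least 140-fold lower number from compound 3 to compound 4 (2.15 log units; beyond the scatter) in size. Compound 4 is estimated at 700 nM in this assay with an expected range of 200 nM to 2500 nM for the measurement.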

Compound 4, half-maximal inhibitory concentration: 1660 nM
For compound 4 the middle estimate is 2.4-fold (0.38 log units) below the measured one, and the stated range covers the measured number.
By their numbers in this assay, from the lowest: compound 1; then compound 4; then compound 2. At a limit, above all of these: compound 3.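

In this assay, 4-chloro-3-fluorophenyl on the amine nitrogen brings the series back from the limit, with an at least 60-fold lower number from compound 3 to compound 4 (1.77 log units; beyond the scatter), so in this set the large loss goes with 4-carboxyphenyl and not with every change away from 3-chlorophenyl. The new group falls within the span of the two earlier measured aryl groups: it improves on 3-(methoxycarbonyl)phenyl, with a 2.5-fold lower number from compound 2 to compound 4 (0.39 log units; beyond the scatter), but gives up some ground against 3-chlorophenyl, with a 2.8-fold higher number from compound 1 to compound 4 (0.44 log units; beyond the scatter). Compound 3 remains the only compound of the four read at a limit, which is not a number, so its steps give only a minimum size: the limit of > 100000 nM in this assay, at which 1 of the 4 values shown sits.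

The compounds shown leave open how the difference between 3-chlorophenyl and 4-chloro-3-fluorophenyl divides between the fluoro group and the shifted chloro group, a question that 3-chloro-4-fluorophenyl or 4-chlorophenyl would bear on. They also leave open whether the loss with 4-carboxyphenyl extends to 3-carboxyphenyl, or persists in 4-(methoxycarbonyl)phenyl, 4-aminophenyl or a carboxylic acid held on a longer chain.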